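This account rests on a few compounds, and the source may have more. Where it says the series, first, only, none or still open, it means among the compounds named here.

Measured compounds in a functional assay on HepG2 cells (Homo sapiens) for cytotoxicity, read by MTT assay; a higher number here means a weaker inhibitor, a lower number a stronger inhibitor:
Compound 1 `Cc1nc2c(s1)C(=O)C=C(Nc1ccc(OC(F)(F)F)cc1)C2=O` gives > 100 ug/mL, a limit of the assay rather than a number.
Compound 2 `Cc1nc2c(s1)C(=O)C=C(Nc1cccc(Br)c1)C2=O` gives 15 ug/mL.
Compound 3 `CCOc1ccc(NC2=CC(=O)c3ncsc3C2=O)cc1` gives 23.6 ug/mL.

Among the two compounds that return a number in this assay, compound 3 has the higher value, and compound 2 sits close enough to it that the gap between the two lies within the usual scatter of the method. The third result is not a number at all: compound 1 reaches only the limit of the assay, which is recorded as the limit of > 100 ug/mL in this assay, at which 1 of the 3 values shown sits.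

Compound 4 `O=C1C=C(Nc2ccc(OC(F)(F)F)cc2)C(=O)c2scnc21` has not yet been measured in this assay. It differs from compound 3 in one place: trifluoromethyl in place of ethyl on an oxygen on an aromatic ring. Among the compounds with values here, no pair of measured compounds differs by exactly this change, so the size of the step can only be anticipated. Within the data shown here, the one measured compound that carries a trifluoromethoxy group, compound 1, reached only a limit, and that tilts the expectation towards a weaker inhibitor. The step from compound 3 to compound 4 is therefore expected to be upward, at a 2.5-fold higher number from compound 3 to compound 4 (0.41 log units; beyond the scatter). Compound 4 is estimated to give 60 ug/mL, with a likely range from 25 ug/mL to 150 ug/mL, and a real chance that it too is reported only as a limit.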

Compound 4, half-maximal inhibitory concentration: > 100 ug/mL
Compound 4 ended at the assay's limit (the forecaster's own chance of this, stated with the estimate: 35%); middle value at least 1.6-fold (0.22 log units) from the limit.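

Within the data shown here, compounds 3 and 4 are the first measured pair that differ in one place, so swapping ethoxy for trifluoromethoxy on the aromatic ring can now be read directly in this assay as a clear move towards weaker inhibition (an at least 4.2-fold higher number from compound 3 to compound 4 (0.62 log units; beyond the scatter)). Compound 4 gives > 100 ug/mL, which is a limit of the assay and not a number, so this step has a known lower bound but no known full size. The result shows that this single change at this place is enough to take a compound that returns a number to the limit, a result that now recurs within the small set: the limit of > 100 ug/mL in this assay, at which 2 of the 4 values shown sit.

The compounds shown leave open how other groups on that oxygen would behave: a methyl group or a longer chain such as butyl might stay close to compound 3 or might also reach the limit. They also leave open what would happen if an amine or a carboxylic acid replaced the whole ethoxy group on the aromatic ring, and a numerical value for the trifluoromethoxy step would require a reading beyond the limit of this assay.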